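Moving fluorine from 2-fluorobenzyl to 3-fluorobenzyl

The compounds below may be only part of what the source reports. "The series", "measured", "known", "first", "only" and "open" are said of these compounds alone.

compound 1 `O=C(Nc1ccc(Cl)c(Cl)c1)Nc1cc2ncncc2cc1OCc1ccccc1F` gives > 10000 nM
compound 2 `O=C(Nc1cccc(F)c1)Nc1cc2ncncc2cc1OCc1ccccc1Cl` gives 2400 nM
compound 3 `O=C(Nc1ccccc1F)Nc1cc2ncncc2cc1OCc1ccccc1F` gives 3800 nM

All three values come from a functional assay on GBM3 cells (Homo sapiens) for antiproliferative activity, read by WST assay, with a stated time of 72 h (on this read-out higher numbers stand for weaker inhibition and lower numbers for stronger inhibition), and are compared on that read-out. For compound 1 the entry > 10000 nM is a limit and not a number. Compound 3 stands at 3800 nM and compound 2 at 2400 nM lies within the scatter of it.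

Compound 4 `O=C(Nc1ccccc1F)Nc1cc2ncncc2cc1OCc1cccc(F)c1` has not yet been measured. Its difference from compound 3 is 3-fluorophenyl in place of 2-fluorophenyl on a saturated chain carbon bound to an oxygen on an aromatic ring and, cut one bond further out, it reads 2-fluorobenzyl to 3-fluorobenzyl.

Only one measured step links two of these compounds in a single place, namely an at least 2.6-fold lower number from compound 1 to compound 3 (0.42 log units; beyond the scatter) and it concerns the group on an amide-type nitrogen, not the place that changes here. Going by the values given here, no measured step tests the new change directly, so no shift beyond the scatter is expected in this assay and neither direction is favoured. Among the compounds with values here, the expectation starts from compound 3 at 3800 nM and takes no size from the step at the other place.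

The expected step is a 1.1-fold lower number from compound 3 to compound 4 (0.04 log units; within the scatter) and it is meant as no change beyond the scatter. Compound 4 is estimated at 3500 nM with an expected range from 1200 nM to 9000 nM.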

Compound 4, half-maximal inhibitory concentration: 8100 nM
The estimate for compound 4 lay 2.3-fold (0.36 log units) below the measured number, within the range that was stated.
By their numbers in this assay, from the lowest: compounds 2 and 3 (each within the scatter of the next); then compound 4. At a limit, above all of these: compound 1.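

In this assay, replacing 2-fluorobenzyl with 3-fluorobenzyl gave a 2.1-fold higher number from compound 3 to compound 4 (0.33 log units; beyond the scatter), so the place of the fluorine on this group is not neutral for the antiproliferative read-out. Going by these compounds alone, the earlier compounds offered one measured step, and that step lay on the group on an amide-type nitrogen; this is the first step measured at the benzyl group on the oxygen, and it goes towards weaker inhibition. Compound 3 and compound 4 hold the same atoms joined differently, and the leaving and entering groups have the same counts, so the shift belongs to the placement of the fluorine alone, although it rests on this single pair.

The compounds shown leave open whether an unsubstituted benzyl group, a methoxy group in place of the fluorine, or a longer chain such as phenethyl would be tolerated at this place, and whether the same fluorine move would hold with another group on the amide-type nitrogen. Compound 1, with 3,4-dichlorophenyl on that nitrogen, gives a limit and not a number, so it offers no measured starting point for such a comparison: the limit of > 10000 nM in this assay, at which 1 of the 4 values shown sits.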